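Replacing the carboxy azetidine of compound 2

A few compounds are considered here, and "the series" means these few. Any claim that something is new, unique, unknown or untested is made for them only; others in the source may bear on it.

Measured in a functional assay on HeLa cells (Homo sapiens) for antiproliferative activity, read by CCK-8 assay, with a stated time of 48 h; a lower number here means a stronger inhibitor, a higher number a weaker inhibitor:
compound 1 `COc1ccc(/C=C\c2cc(OC)c(OC)c(OC)c2)cc1OCc1ccc(CN[C@H](C(=O)O)[C@H](C)O)cc1` gives > 10000 nM, a limit of the assay
compound 2 `COc1ccc(/C=C\c2cc(OC)c(OC)c(OC)c2)cc1OCc1ccc(CN2CC(C(=O)O)C2)cc1` gives 6500 nM

Of these two compounds, only compound 2 has an actual number, 6500 nM. The value of compound 1 is a limit, so compound 2 cannot be placed precisely against it. Within the data shown here, the only measured step is an at least 1.5-fold lower number from compound 1 to compound 2 (0.18 log units; that floor lies within the scatter). That step exchanges one carboxy-bearing side chain for another, and its floor lies within the scatter.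

Compound 3 `COc1ccc(/C=C\c2cc(OC)c(OC)c(OC)c2)cc1OCc1ccc(CN2CC[C@H](O)C2)cc1` differs from compound 2 in one place: 3-hydroxypyrrolidin-1-yl in place of 3-carboxyazetidin-1-yl on a saturated chain carbon bound to an aromatic carbon. The change sits on a saturated chain carbon bound to an aromatic carbon. Unlike compound 1 and compound 2, compound 3 carries no carboxy group, and no measured step shows what removing that group does. The evidence for a size is therefore thin. Compound 2 gives 6500 nM with the carboxy group in place, and a lower number is expected in this assay once it is gone. The expected change is a 26-fold lower number from compound 2 to compound 3 (1.41 log units; beyond the scatter). For compound 3 the estimate is 250 nM, with an expected range from 20 nM to 4000 nM.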

Compound 3, half-maximal inhibitory concentration: 10500 nM
The estimate for compound 3 lay 42-fold (1.62 log units) below the measured number, and the stated range ends below it.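

In this assay, among these compounds, compound 3 is the first compound here with no carboxy group on the saturated chain carbon bound to an aromatic carbon, and the exchange gives a 1.6-fold higher number from compound 2 to compound 3 (0.21 log units; within the scatter). In this one pair, then, losing the carboxy group comes with no difference that can be told from the scatter, although the same exchange also replaces a four-membered ring with a five-membered one and brings in a defined stereocentre, so the pair cannot separate these parts. The step from compound 1 to compound 3 cannot be read, and what stands in its way is a limit: the limit of > 10000 nM in this assay, at which 1 of the 3 values shown sits.

With only three side chains shown, it remains open whether any group on this carbon can bring the number in this assay well down from where compound 2 and compound 3 stand. A pyrrolidine-3-carboxylic acid would part ring size from the carboxy group, while a plain pyrrolidine or a dimethylamine would show whether the hydroxy group of compound 3 counts at all.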